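This account rests on a few compounds, and the source may have more. Where it says the series, first, only, none or still open, it means among the compounds named here.

Measured so far:
- compound 1 `CN(C)CCNc1ccnc2cc(OCc3ccc(F)cc3)ccc12`: 810 nM
- compound 2 `CCCCCCCCOc1ccc2c(Cl)ccnc2c1`: 4500 nM

In a functional assay on DLD-1 cells (Homo sapiens) for cytotoxicity, read by MTT assay, with a stated time of 48 h (a higher number here means a weaker inhibitor, a lower number a stronger inhibitor), compound 1 gives 810 nM, the lowest of the two numbers at hand. Compound 2 gives 4500 nM, a gap from compound 1 that lies beyond the scatter. Going by the values given here, compound 2 differs from compound 1 in more than one place, so no single step can be drawn between the two; only the two values themselves are known.

Compound 3 `C=CCOc1ccc2c(NCCN(C)C)ccnc2c1` has not been measured in this assay. It differs from compound 1 by vinyl in place of 4-fluorophenyl on a saturated chain carbon bound to an oxygen on an aromatic ring; cut one bond further out, the same difference reads 4-fluorobenzyl to allyl. Among the compounds with values here, no step between measured compounds matches this change, so the expectation rests on compound 1 alone. A modest step toward a higher number is expected, a 2.0-fold higher number from compound 1 to compound 3 (0.30 log units; within the scatter), although a shift within the scatter would not surprise. Compound 3 is estimated at 1600 nM, with a range of 600 nM to 4500 nM.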

Compound 3, half-maximal inhibitory concentration: 1530 nM
For compound 3 the middle estimate is 1.0-fold (0.02 log units) above the measured one; the measured number falls inside the stated range.
By their numbers in this assay, from the lowest: compounds 1 and 3 (each within the scatter of the next); then compound 2.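

Vinyl in place of 4-fluorophenyl on a saturated chain carbon bound to an oxygen on an aromatic ring gives a 1.9-fold higher number from compound 1 to compound 3 (0.28 log units; within the scatter) in this assay and so provides the first single-place comparison in the series, which compound 2 could not provide. Between compound 1 and compound 3, the loss of the six-membered aromatic ring and its fluorine, with 7 heavy atoms leaving and 2 entering, produces no difference that can be separated from the scatter. Nothing available explains why these two compounds read alike.

Still open, going by these compounds, is whether a chain ending in an amine or a carboxylic acid at this place would stay within the scatter of compound 1. The compounds shown also do not settle how unsubstituted benzyl or a longer chain such as hexyl would read here.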